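The compounds below may be only part of what the source reports. "The series", "measured", "known", "first", "only" and "open" are said of these compounds alone.

Compound 1 `COc1cc(OC)n2cc(-c3ccc(NCc4ccccc4)cc3)nc2n1` and compound 2 `COc1cc(OC)n2cc(-c3ccc(N(Cc4ccccc4)Cc4ccccc4)cc3)nc2n1` share one core, while compound 3 `Cc1ccn2cc(-c3ccc(NCc4ccccc4)cc3)nc2c1` and the as-yet-unmeasured compound 4 `Cc1ccn2cc(-c3ccc(N(Cc4ccccc4)Cc4ccccc4)cc3)nc2c1` share another; the difference between the two cores is not broken down here. All were examined in a functional assay on HT-29 cells (Homo sapiens) for antiproliferative activity, read by MTT assay, with a stated time of 72 h; a lower number here means a stronger inhibitor of growth, a higher number a weaker inhibitor of growth. For compound 1 the result in this assay is a limit of the assay, > 100000 nM. For compound 2 the result in this assay is likewise a limit, > 100000 nM. Compound 3 is the only one of the three with a measured number, giving 17500 nM in this assay.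

The change from compound 1 to compound 2 is benzyl in place of hydrogen on a nitrogen on an aromatic ring. Its size, a step that the two limits leave unreadable from compound 1 to compound 2, cannot be read, because the limit of > 100000 nM in this assay, at which 2 of the 3 values shown sit, holds both of its ends. The change from compound 3 to compound 4 is the same one, (benzyl in place of hydrogen on a nitrogen on an aromatic ring), carried out on the other core.

Within the data shown here, with the only measured instance of this change unreadable, the expectation for compound 4 rests on compound 3 alone, whose value of 17500 nM in this assay is the starting point. The measured pair offers no direction to lean on. The step from compound 3 to compound 4 in this assay is expected to be small, a 1.7-fold higher number from compound 3 to compound 4 (0.23 log units; within the scatter). Compound 4 is therefore estimated at 30000 nM in this assay, with a plausible range from 8000 nM to 100000 nM, and a real chance that the assay returns only a limit.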

Compound 4, concentration for 50% growth inhibition: 6900 nM
Beside the measured number, compound 4's estimate is 4.3-fold (0.64 log units) above it, and the stated range ends above it.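

On the core of compound 3, adding the benzyl to the nitrogen gives a readable result in this assay: there is a 2.5-fold lower number from compound 3 to compound 4 (0.40 log units; beyond the scatter), a modest gain in growth inhibition rather than a loss. The same change on the other core, from compound 1 to compound 2, gives no readable size or direction, and the two cores cannot be compared for this change, because both ends of that step sit at a limit: the limit of > 100000 nM in this assay, at which 2 of the 4 values shown sit. The series therefore holds one readable instance of this change, which shows that it can lower the number on one core but does not show that the effect carries over from one core to another.

The compounds shown leave open whether a group other than benzyl on this nitrogen, such as a methyl, a longer chain ending in an amine, or a benzyl ring bearing a carboxylic acid, would move the number further on the core of compound 3. They also leave open whether any substitution on the core of compound 1 would give a measured number in this assay, since the results for compound 1 and compound 2 are limits.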